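Adding a methoxy group to compound 3

The compounds below may be only part of what the source reports. "The series", "measured", "known", "first", "only" and "open" are said of these compounds alone.

All three measured compounds share one core and differ only in the group attached through an oxygen or a nitrogen to that core. Compound 1 `Nc1cc(N)c2nc(-c3ccccc3)c(Oc3ccc(Cl)c(Cl)c3)nc2c1` carries an oxygen-linked group; in a functional assay on MDA-MB-231 cells (Homo sapiens) for inhibition, read by sulforhodamine B assay, with a stated time of 48 h (on this read-out higher numbers stand for lower toxicity in this test and lower numbers for higher toxicity in this test), compound 1 gives 66100 nM. Compound 2 `Nc1cc(N)c2nc(-c3ccccc3)c(NCc3ccc(Cl)c(Cl)c3)nc2c1` carries a nitrogen-linked chain; in this assay compound 2 gives only a limit of the assay, < 100000 nM. Compound 3 `COc1ccc(CNc2nc3cc(N)cc(N)c3nc2-c2ccccc2)cc1OC` keeps that nitrogen-linked chain with two methoxy groups on its ring; in this assay compound 3 gives 79400 nM, the highest of the two numbers, with compound 1 within the usual scatter of it. The step from compound 2 to compound 3 is a step that the limit leaves unreadable from compound 2 to compound 3, because of the limit of < 100000 nM in this assay, at which 1 of the 3 values shown sits, its size cannot be read.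

Compound 4 `COc1cc(CNc2nc3cc(N)cc(N)c3nc2-c2ccccc2)cc(OC)c1OC` differs from compound 3 by methoxy in place of hydrogen on an aromatic carbon. Going by the values given here, no measured step touches this kind of change, and the only neighbouring step is unreadable, so no direction can be drawn from the data. The step from compound 3 to compound 4 is therefore expected to be a 1.1-fold lower number from compound 3 to compound 4 (0.02 log units; within the scatter), within the scatter. For compound 4 the expected value in this assay is 75000 nM, with a range from 35000 nM to 160000 nM.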

Compound 4, concentration lethal to 50% of the cells: 31600 nM
The estimate for compound 4 lay 2.4-fold (0.38 log units) above the measured number; measured number outside the range, below it.
By their numbers in this assay, from the lowest: compound 4; then compounds 1 and 3 (each within the scatter of the next).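

Placing methoxy in place of hydrogen on this aromatic carbon, ortho to a methoxy group, gives a 2.5-fold lower number from compound 3 to compound 4 (0.40 log units; beyond the scatter) in this assay. Going by these compounds alone, this is the first readable step, and it shows that a change on this ring can move the number beyond the scatter, here towards higher toxicity in this test. The earlier compounds could not show this, since their only step rests on compound 2, whose value is a limit: the limit of < 100000 nM in this assay, at which 1 of the 4 values shown sits.

A single step cannot show whether the shift belongs to methoxy itself or would also appear with another group at this position, such as a hydroxyl, an amine or an ethoxy group. Going by these compounds, whether the same change would act alike on the oxygen-linked compound 1 also remains open.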